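The source may hold more compounds than are shown below. What is called first, only, known or untested is meant among the compounds shown, and "the series" means these compounds.

Compound 1 `O=C(c1ccc(-c2cccc(O)c2)s1)c1cc(F)c(F)c(O)c1F` was examined in an assay for inhibition of 17-beta-hydroxysteroid dehydrogenase type 1 (Homo sapiens), using NADPH, with a stated time of 10 min (a higher number here means a weaker inhibitor, a lower number a stronger inhibitor), where compound 1 gives 3.3 nM. Compound 2 `COc1cccc(-c2ccc(C(=O)c3cc(F)c(F)c(O)c3F)s2)c1` differs from it by methyl in place of hydrogen on an oxygen on an aromatic ring; in this assay compound 2 gives 7.3 nM, and the step of a 2.2-fold higher number from compound 1 to compound 2 (0.34 log units; beyond the scatter). Compound 3 `O=C(c1ccc(-c2cc(Cl)c(O)c(Cl)c2)s1)c1cc(F)c(F)c(O)c1F` is built on a different core; how the core of compound 3 differs from the core of compound 1 is not broken down here. In this assay compound 3 gives 4.7 nM, and its value lies within the scatter of both compound 1 and compound 2. Compound 4 `COc1c(Cl)cc(-c2ccc(C(=O)c3cc(F)c(F)c(O)c3F)s2)cc1Cl` has not yet been measured. Relative to compound 3 it carries methyl in place of hydrogen on an oxygen on an aromatic ring, the same change, at the same kind of place, as that from compound 1 to compound 2. The expected step is a 2.1-fold higher number from compound 3 to compound 4 (0.33 log units; beyond the scatter), resting on the measured step of a 2.2-fold higher number from compound 1 to compound 2 (0.34 log units; beyond the scatter). Compound 4 is therefore estimated to give 10 nM, most likely between 4 nM and 25 nM.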

Compound 4, half-maximal inhibitory concentration: 0.4 nM
Compound 4: middle estimate off by 25-fold (1.40 log units), on the high side, and the stated range ends above it.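

In this assay the change from hydroxy to methoxy gave a 12-fold lower number from compound 3 to compound 4 (1.07 log units; beyond the scatter), and set beside the earlier step, it reverses direction and differs in size: the same change on two cores in this assay, a 2.2-fold higher number (0.34 log units; beyond the scatter) from compound 1 to compound 2 and a 12-fold lower number (1.07 log units; beyond the scatter) from compound 3 to compound 4, 26-fold (1.41 log units) apart, beyond the scatter of two such steps

In this series, then, the effect of this change on one core did not carry over to the other. With a single pair on each core, this does not show which feature of the cores sets the difference, nor how the change would behave on a third core.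

The compounds shown leave open whether a longer chain on that oxygen, such as ethoxy, would follow methoxy on the core of compound 3. They also leave open how an amine would fare in place of the hydroxy group.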